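Notes on compound 4: 5-methylthiophen-2-yl for thiophen-3-yl

A few compounds are considered here, and "the series" means these few. Any claim that something is new, unique, unknown or untested is made for them only; others in the source may bear on it.

Of the compounds shown here, three have been measured. Compound 1 `C#CC(=O)Nc1ccc2c(c1)/C(=C/c1ccc[nH]1)C(=O)N2` gives 4400 nM in a functional assay on HeLa cells (Homo sapiens) for antiproliferative activity, read by MTT assay, with a stated time of 72 h; on this read-out higher numbers stand for weaker inhibition and lower numbers for stronger inhibition. Compound 2 `C=C(Br)C(=O)Nc1ccc2c(c1)/C(=C\c1ccsc1)C(=O)N2` gives 2600 nM in this assay, and compound 3 `C=C(Br)C(=O)Nc1ccc2c(c1)/C(=C/c1ccsc1)C(=O)N2` gives 3500 nM in this assay. Compound 2 carries the lowest of the three numbers, but its distance to compound 3 and to compound 1 lies within the scatter, so no order among the three can be read from these values. For the measured compounds named here, the only single-point step so far is a 1.3-fold higher number from compound 2 to compound 3 (0.13 log units; within the scatter), and this flat result fits (the fact that compounds 2 and 3 differ only in the configuration as drawn).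

Compound 4 `C=C(Br)C(=O)Nc1ccc2c(c1)/C(=C\c1ccc(C)s1)C(=O)N2` is not yet measured. Against compound 2 the change is 5-methylthiophen-2-yl in place of thiophen-3-yl on a double-bonded chain carbon bound to a double-bonded ring carbon. Going by the values given here, none of the measured steps touches this change: the one available step concerns the drawn configuration of the double bond, not the ring on the double-bonded chain carbon, and compound 1 differs from compound 2 in more than one place, so its value shows only that a different ring with a different amide gives a number within the scatter of compound 2. No step beyond the scatter is therefore expected in this assay in either direction. The expected step is no change at the digits printed from compound 2 to compound 4 (within the scatter). Compound 4 is estimated at 2600 nM, with a range from 900 nM to 7500 nM.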

Compound 4, half-maximal inhibitory concentration: 2000 nM
Compound 4: middle estimate off by 1.3-fold (0.11 log units), on the high side; the range from low to high includes it.
By their numbers in this assay, from the lowest: compounds 4, 2, 3 and 1 (each within the scatter of the next, the first and the last beyond it).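

In this assay, for the compounds shown here, the first change of the ring on the double-bonded chain carbon gives a 1.3-fold lower number from compound 2 to compound 4 (0.11 log units; within the scatter). At this place, then, 5-methylthiophen-2-yl can stand in place of thiophen-3-yl without a readable step in this read-out, although the entering group has 6 heavy atoms against 5 and the point of attachment on the thiophene differs; hydrogen-bond donor and acceptor counts and net charge are unchanged. This holds for one pair only, with the bromoacrylamide and the drawn configuration of compound 2 kept, so it marks this one exchange as flat and gives no trend for the position. Nothing available explains why this step comes out as it does:.

The compounds shown do not separate the methyl group from the point of attachment, which an unsubstituted thiophen-2-yl would do, nor do they say whether the other drawn configuration of the double bond would stay as flat with the 5-methylthiophen-2-yl group. Also open, as far as these compounds go, is whether the number would hold with a longer chain such as butyl in place of the methyl, or with an amine or a carboxylic acid on the thiophene.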